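A few compounds are considered here, and "the series" means these few. Any claim that something is new, unique, unknown or untested is made for them only; others in the source may bear on it.

Measured in an ADME assay on HEL cells (Homo sapiens) for cytotoxicity (a higher number here means that more compound is tolerated, a lower number that less compound is tolerated), are:
compound 1 `O=C(COc1cccc2ccccc12)N/N=C/c1ccc(O)cc1` with 60.6 ug/mL
compound 2 `O=C(COc1cccc2ccccc12)N/N=C/c1ccc(Br)cc1` with 100 ug/mL
compound 3 `CSc1ccc(/C=N/NC(=O)COc2cccc3ccccc23)cc1` with > 100 ug/mL (a limit)

Compound 3 stands at > 100 ug/mL as a limit of the assay and not as a number. Compound 4 `O=C(COc1cccc2ccccc12)N/N=C/c1ccccc1Cl` carries 2-chlorophenyl in place of 4-(methylsulfanyl)phenyl on a carbon with a double bond to nitrogen. The measured steps bear on this change only loosely, for each of them swaps a single group on an aromatic carbon and leaves the rest of that aromatic ring as it is. Bromo in place of hydroxy gives a 1.7-fold higher number from compound 1 to compound 2 (0.22 log units; within the scatter) and methylsulfanyl in place of hydroxy gives an at least 1.6-fold higher number from compound 1 to compound 3 (0.21 log units; that floor lies within the scatter) while methylsulfanyl in place of bromo gives a number no lower from compound 2 to compound 3 (the limit leaves the size open) and none of these is shown beyond the scatter. Within the data shown here, the nearest measured case with a halogen is compound 2 at 100 ug/mL and no chloro compound has been measured. A step beyond the scatter is therefore not expected in this assay for this change, though a small move to a lower number would not surprise. The step expected here is an at least 1.1-fold lower number from compound 3 to compound 4 (0.07 log units; that floor lies within the scatter) as an estimate. For compound 4 the estimate is 85 ug/mL with an expected range from 45 ug/mL to 100 ug/mL in this read-out.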

Compound 4, half-maximal cytotoxic concentration: 62.7 ug/mL
Beside the measured number, compound 4's estimate is 1.4-fold (0.13 log units) above it; the range from low to high includes it.
By their numbers in this assay, from the lowest: compounds 1, 4 and 2 (each within the scatter of the next).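

In this assay, among these compounds, compound 4 shows that the whole aryl group on the carbon with a double bond to nitrogen can change, not only a single group on an aromatic carbon, without a step beyond the scatter: 2-chlorophenyl in place of 4-bromophenyl gives a 1.6-fold lower number from compound 2 to compound 4 (0.20 log units; within the scatter), and 2-chlorophenyl in place of 4-hydroxyphenyl gives a 1.0-fold higher number from compound 1 to compound 4 (0.01 log units; within the scatter). Set against 4-(methylsulfanyl)phenyl, the same group gives an at least 1.5-fold lower number from compound 3 to compound 4 (0.20 log units; that floor lies within the scatter), so the floor of this step also stays within the scatter, while its full size remains unknown. Compound 3 stands at > 100 ug/mL, which is a limit and not a number: the limit of > 100 ug/mL in this assay, at which 1 of the 4 values shown sits.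

The compounds shown cannot separate the effect of the halogen from that of its place, since 2-chlorophenyl and 4-bromophenyl differ in both. They also leave open whether an amine or a carboxylic acid on this aromatic ring, or a longer chain in place of the ring, would move this assay beyond the scatter, and the same question stands for any change to the shared core.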